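This account rests on a few compounds, and the source may have more. Where it says the series, first, only, none or still open, it means among the compounds named here.

Of the compounds shown here, two of a shared core have been measured in a functional assay on SGC-7901 cells (Homo sapiens) for antiproliferative activity, read by MTT assay, with a stated time of 24 h; a higher number here means a weaker inhibitor, a lower number a stronger inhibitor. Compound 1 `Cc1cccc(-n2cc(-c3cccc(NS(=O)(=O)c4c[nH]c(=O)[nH]c4=O)c3)nn2)c1` gives 9100 nM in this assay. Among the measured compounds shown here, compound 2 `O=c1[nH]cc(S(=O)(=O)Nc2cccc(-c3cn(-c4cccc(Cl)c4)nn3)c2)c(=O)[nH]1` gives 3950 nM in this assay, the lower of the two numbers; the one measured step, a 2.3-fold lower number from compound 1 to compound 2 (0.36 log units; beyond the scatter), separates it from compound 1. Compound 3 `O=c1[nH]cc(S(=O)(=O)Nc2cccc(-c3cn(-c4ccc(Cl)cc4)nn3)c2)c(=O)[nH]1` is not yet measured. The change from compound 2 to compound 3 is 4-chlorophenyl in place of 3-chlorophenyl on an aromatic nitrogen; the chlorine is kept and only its place on the ring moves. For the measured compounds named here, no measured step bears directly on such a move, since the step from compound 1 to compound 2 exchanged the group itself rather than its position. That step was modest, so the frame for any shift here is narrow. Going by the values given here, with the same atoms joined differently and no comparable step among the measured compounds, no shift beyond the scatter is expected in this assay, and the estimated step is a 1.0-fold higher number from compound 2 to compound 3 (0.01 log units; within the scatter). Compound 3 is therefore expected to give about 4000 nM in this assay, with a range from 1500 nM to 11000 nM.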

Compound 3, half-maximal inhibitory concentration: 2160 nM
Compound 3: middle estimate off by 1.9-fold (0.27 log units), on the high side; low and high end bracket the measured number.
By their numbers in this assay, from the lowest: compounds 3 and 2 (each within the scatter of the next); then compound 1.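

Moving the chlorine on the aromatic nitrogen's ring, 4-chlorophenyl in place of 3-chlorophenyl, gives a 1.8-fold lower number from compound 2 to compound 3 (0.26 log units; within the scatter) in this assay, so within this pair the place of the chlorine cannot be told apart from repeat scatter, something the earlier exchange of methyl for chloro could not show. The exchange of 3-methylphenyl for 4-chlorophenyl gives a 4.2-fold lower number from compound 1 to compound 3 (0.62 log units; beyond the scatter) in this assay, and this step, like a 2.3-fold lower number from compound 1 to compound 2 (0.36 log units; beyond the scatter) in the same read-out, lies beyond the scatter, so among these three compounds both chlorophenyl groups stand apart from the 3-methylphenyl group, with no compound shown going against this. Nothing available here accounts for either the small step or the larger ones.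

Because compound 1 differs from compound 3 in both the group and its place, the compounds shown leave open what a 4-methylphenyl group would give on the same nitrogen, which would separate the two changes. They also leave open how a 4-aminophenyl or 4-carboxyphenyl group, with an amine or a carboxylic acid on this ring, would read in this assay as a test of how far this position tolerates change.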